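Notes on the series: 3-nitrophenyl in place of 4-chlorophenyl

A few compounds are considered here, and "the series" means these few. Any claim that something is new, unique, unknown or untested is made for them only; others in the source may bear on it.

Compound 1 `Cc1nnc(Sc2cc(NC(=O)c3ccc(Cl)cc3)c3ccccc3c2O)s1` gives 49500 nM in a functional assay on PC-3 cells (Homo sapiens) for antiproliferative activity, read by MTT assay, with a stated time of 48 h; on this read-out higher numbers stand for weaker inhibition and lower numbers for stronger inhibition. Compound 2 `O=C(/C=C/c1ccc([N+](=O)[O-])cc1)Nc1cc(Sc2ncn[nH]2)c(O)c2ccccc12` returns only a limit in this assay, > 100000 nM. Compound 3 `O=C(Nc1cc(Sc2ncn[nH]2)c(O)c2ccccc12)c1ccc(Cl)cc1` gives 5520 nM in this assay, the lowest of the two numbers shown; its nearest neighbour is compound 1, reached by a 9.0-fold lower number from compound 1 to compound 3 (0.95 log units; beyond the scatter), a change on the sulfur rather than on the carbonyl carbon. Compound 4 `O=C(Nc1cc(Sc2ncn[nH]2)c(O)c2ccccc12)c1cccc([N+](=O)[O-])c1` differs from compound 3 by 3-nitrophenyl in place of 4-chlorophenyl on a carbonyl carbon. Within the data shown here, no measured step changes the group on the carbonyl carbon, so none bears directly on this change, and no step beyond the scatter is expected in this assay. Compound 4 is therefore estimated at 8000 nM, within 2500 nM to 30000 nM, meaning an expected step of a 1.4-fold higher number from compound 3 to compound 4 (0.16 log units; within the scatter).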

Compound 4, half-maximal inhibitory concentration: 26900 nM
The estimate for compound 4 lay 3.4-fold (0.53 log units) below the measured number, and the stated range covers the measured number.
By their numbers in this assay, from the lowest: compound 3; then compounds 4 and 1 (each within the scatter of the next). At a limit, above all of these: compound 2.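

In this assay the group on the carbonyl carbon proves not to be silent: with the 1H-1,2,4-triazol-5-yl on the sulfur held fixed, 3-nitrophenyl in place of 4-chlorophenyl gives a 4.9-fold higher number from compound 3 to compound 4 (0.69 log units; beyond the scatter). Among these compounds, this is the first readable step at this place, so the carbonyl substituent joins the sulfur substituent as a site where a single change moves the number beyond the scatter. Nothing at hand gives a cause for this step.

The compounds shown leave open whether the nitro group or its ring position carries the step, which a 3-chlorophenyl group on the same carbonyl carbon would separate. As far as these compounds go, how a 3-aminophenyl group would read there also remains open.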